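The source may report more compounds than this note shows. Statements on the series, on what has been measured and on what is new or still open speak of the compounds shown alone.

Compound 2 `CC(=O)c1cc(-c2ccc(F)cc2)cc2cc(-c3ccc(F)cc3)[nH]c12` gives 71.6% in a functional assay on HeLa cells (Homo sapiens) for cytotoxicity, read by MTT assay, with a stated time of 2 days, tested at 1 uM (a higher number here means a weaker effect of the compound at the concentration tested, a lower number a stronger effect), the second highest of three numbers: compound 1 `CC(=O)c1cc(-c2ccc(F)cc2)cc2cc(-c3ccccc3)[nH]c12` gives 82.7%, and compound 3 `COc1ccc(-c2cc3cc(-c4ccc(F)cc4)cc(C(C)=O)c3[nH]2)cc1` gives 62.9%, within the scatter of compound 2. Compound 4 `CC(=O)c1cc(/C=C/c2ccccc2)cc2cc(-c3ccc(F)cc3)[nH]c12` differs from compound 2 by 2-phenylethenyl in place of 4-fluorophenyl on an aromatic carbon. Among the compounds with values here, none of the measured steps touches the group that leaves here; the known steps of a number 11.1 percentage points lower from compound 1 to compound 2 (beyond the scatter) and a number 19.8 percentage points lower from compound 1 to compound 3 (beyond the scatter) change a substituent on the other six-membered aromatic ring and were modest, while a number 8.7 percentage points lower from compound 2 to compound 3 (within the scatter) stayed within the scatter. Within the data shown here, with no direct precedent, a modest drop or no step beyond the scatter is expected, giving a number 3.6 percentage points lower from compound 2 to compound 4 (within the scatter). Compound 4 is therefore estimated at 68%, with a range from 50% to 88%.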

Compound 4, a percentage reported as activity, at one concentration (the size of the read-out at that concentration, not a potency): 60.5%
Beside the measured number, compound 4's estimate is 7.5 percentage points above it; measured number inside the range.
By their numbers in this assay, from the lowest: compounds 4, 3 and 2 (each within the scatter of the next, the first and the last beyond it); then compound 1.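

In this assay, within the data shown here, the earlier compounds all keep 4-fluorophenyl at this position, meta to an acetyl group, so this is the first change seen there. Putting 2-phenylethenyl in its place gives a number 11.1 percentage points lower from compound 2 to compound 4 (beyond the scatter) and so a modest gain in effect at the concentration tested, showing that this position can change the read-out and still accepts a group with a double bond outside aromatic rings. No measurement at hand explains this step.
From the compounds shown here alone, whether an amine, a carboxylic acid or a longer alkyl chain at this position would shift the number remains open. So does whether the step would persist with a different substituent on the other aromatic ring.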